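Furan-2-yl in place of thiophen-2-yl: what compound 4 may give

The compounds below may be only part of what the source reports. "The series", "measured", "known", "first", "only" and "open" are said of these compounds alone.

Measured so far in an ADME assay on BJ cells (Homo sapiens), read by MTT assay, with a stated time of 72 h; on this read-out lower numbers stand for stronger inhibition and higher numbers for weaker inhibition:
Compound 1 `Cc1ncnc2c1c(-c1cccs1)cn2[C@@H]1O[C@H](CO)[C@@H](O)[C@H]1O` gives > 100000 nM, which is a limit of the assay.
Compound 2 `COc1ncnc2c1c(-c1cccs1)cn2[C@@H]1O[C@H](CO)[C@@H](O)[C@H]1O` gives 62800 nM.
Compound 3 `CNc1ncnc2c1c(-c1cccs1)cn2[C@@H]1O[C@H](CO)[C@@H](O)[C@H]1O` gives > 100000 nM, again a limit of the assay.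

Compound 3 thus sits at the limit of > 100000 nM in this assay, at which 2 of the 3 values shown sit, and no number is known for it. Compound 4 `CNc1ncnc2c1c(-c1ccco1)cn2[C@@H]1O[C@H](CO)[C@@H](O)[C@H]1O` differs from compound 3 in a single ring: furan-2-yl in place of thiophen-2-yl on an aromatic carbon. Going by the values given here, none of the measured steps touches this ring; they concern the methyl, methoxy and methylamino groups, with an at least 1.5-fold lower number from compound 1 to compound 2 (0.20 log units; that floor lies within the scatter), an at least 1.5-fold higher number from compound 2 to compound 3 (0.20 log units; that floor lies within the scatter) and a step that the two limits leave unreadable from compound 1 to compound 3. No step beyond the scatter is therefore expected in this assay for compound 4, that is a step that the limit leaves unreadable from compound 3 to compound 4. Compound 4 is estimated at 120000 nM, between 40000 nM and 400000 nM, and will probably again be reported only as a limit.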

Compound 4, half-maximal inhibitory concentration: 5040 nM
The estimate for compound 4 lay 24-fold (1.38 log units) above the measured number; the whole stated range lies above it.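

In this assay the ring on this aromatic carbon clearly matters: furan-2-yl in place of thiophen-2-yl gives an at least 19-fold lower number from compound 3 to compound 4 (1.29 log units; beyond the scatter) and is a large change, although only sulfur gives way to oxygen. The earlier compounds shown here changed only the methyl, methoxy and methylamino groups and showed no readable step beyond the scatter. Compound 3 stands at a limit, so this step is only a floor: the limit of > 100000 nM in this assay, at which 2 of the 4 values shown sit.

As far as these compounds go, whether furan-2-yl has the same effect alongside methoxy or methyl remains open. So does the outcome with a phenyl or pyridyl ring at this place.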